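A few compounds are considered here, and "the series" means these few. Any claim that something is new, unique, unknown or untested is made for them only; others in the source may bear on it.

Measured so far:
compound 1 `COc1ccc(C(=O)c2cc(OC)c(OC)c(OC)c2)c(NC(=O)CO)c1` gives 100 nM
compound 2 `C=C(c1ccc2c(c1)C=CC(C)(C)O2)c1ccc(OC)cc1NC(=O)CO` gives 110 nM

Both values come from a functional assay on A2780 cells (Homo sapiens) for antiproliferative activity, read by MTT assay, with a stated time of 48 h; a lower number here means a stronger inhibitor, a higher number a weaker inhibitor. Compound 2 stands within the scatter of compound 1, so the two cannot be ranked against each other. Going by the values given here, their shared value range is the only guide available for this series.

Compound 3 `C=C(c1ccc2c(c1)C=CC(C)(C)O2)c1ccc(OC)cc1NC(=O)CNC` differs from compound 2 in one place (methylamino in place of hydroxy on a saturated chain carbon bound to a carbonyl carbon): it has methylamino in place of hydroxy on a saturated chain carbon bound to a carbonyl carbon. Among the compounds with values here, no measured pair yet shows what this exchange does. A modest loss in this assay is expected, though an outcome within the scatter remains quite possible. The estimated change is a 1.5-fold higher number from compound 2 to compound 3 (0.16 log units; within the scatter) and carries wide uncertainty. For compound 3 the expected value is 160 nM, within an estimated range of 45 nM to 600 nM.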

Compound 3, half-maximal inhibitory concentration: 320 nM
The estimate for compound 3 lay 2.0-fold (0.30 log units) below the measured number, and the stated range covers the measured number.
By their numbers in this assay, from the lowest: compounds 1 and 2 (each within the scatter of the next); then compound 3.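

In this assay the hydroxy on a saturated chain carbon bound to a carbonyl carbon does not tolerate every exchange: methylamino there gives a 2.9-fold higher number from compound 2 to compound 3 (0.46 log units; beyond the scatter) and this is the only step shown so far that lies beyond the scatter. The hydrogen-bond donor and acceptor counts are the same for both groups and neither carries a net charge, so the loss appears without any change in those counts. The step is modest and rests on a single pair, on the core of compound 2.

On these data alone, an unsubstituted amine, a dimethylamino group, a methoxy group or a longer chain at this place would show whether the change follows from losing the hydroxy or from the methylamino itself, and the same exchange on the core of compound 1 remains open. Nothing shown here accounts for the step.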